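This account rests on a few compounds, and the source may have more. Where it says the series, first, only, none or still open, it means among the compounds named here.

Measured so far:
compound 1 `O=C(O)CC/C=C\CC1COC(c2cccc3ccccc23)OC1c1cccnc1` — 631 nM
compound 2 `CSc1ccccc1OC(C)(C)C1OCC(C/C=C\CCC(=O)O)C(c2cccnc2)O1` — 89.1 nM
compound 3 `CC(C)(Oc1ccccc1O)C1OCC(C/C=C\CCC(=O)O)C(c2cccnc2)O1` — 95.5 nM

These three compounds share a core and were tested in a functional assay for inhibition, with Homo sapiens as the target; a lower number here means tighter binding, a higher number weaker binding. Compound 1 has the highest number of the three, well beyond the scatter from both compound 2 and compound 3, whose values lie within the scatter of each other. For the measured compounds named here, the one measured step, a 1.1-fold higher number from compound 2 to compound 3 (0.03 log units; within the scatter), changes a group on a side ring and does not touch the position altered here, so no measured step bears directly on the change from compound 1 to compound 4.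

Compound 4 `CC(C)(Sc1ccccc1)C1OCC(C/C=C\CCC(=O)O)C(c2cccnc2)O1` differs from compound 1 in this way: a group of 10 heavy atoms (9 carbon, 1 sulfur; one six-membered aromatic ring of carbon only) in place of a group of 10 heavy atoms (10 carbon; 2 six-membered aromatic rings of carbon only), on a saturated ring carbon. The group that enters resembles, in its sulfur-bearing aromatic part and its placement on the core, the groups carried by compound 2 and compound 3, both of which give much lower numbers than compound 1. On that basis a drop beyond the scatter is expected, as a 4.9-fold lower number from compound 1 to compound 4 (0.69 log units; beyond the scatter), placing compound 4 near compound 2 and compound 3. The estimate for compound 4 in this assay is 130 nM, within a range of 50 nM to 350 nM.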

Compound 4, dissociation constant: 200 nM
Estimate against measurement, compound 4: 1.5-fold (0.19 log units) below; the range from low to high includes it.
By their numbers in this assay, from the lowest: compounds 2 and 3 (each within the scatter of the next); then compound 4; then compound 1.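

In this assay, the group on the saturated ring carbon between two ring oxygen atoms changes from naphthalen-1-yl to the phenylsulfanyl-bearing group of compound 4 with a 3.2-fold lower number from compound 1 to compound 4 (0.50 log units; beyond the scatter) as the result, a modest gain at an equal count of heavy atoms. The chain carbon that carries the aromatic group also responds: phenylsulfanyl in place of 2-hydroxyphenoxy gives a 2.1-fold higher number from compound 3 to compound 4 (0.32 log units; beyond the scatter) and phenylsulfanyl in place of 2-(methylsulfanyl)phenoxy gives a 2.2-fold higher number from compound 2 to compound 4 (0.35 log units; beyond the scatter) on the same carbon. So an aromatic ring at this place is not all that counts: what links it and what it carries also shift the number.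

Phenylsulfanyl differs from those two groups in both its linking atom and its missing ring substituent, and only an unsubstituted phenoxy or a 2-hydroxyphenylsulfanyl group would separate these two changes. No measured evidence here explains any of these steps.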